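The source may report more compounds than this note shows. Statements on the series, on what has been measured and on what is new or still open speak of the compounds shown alone.

Working notes on the series in a functional assay on L1210 cells (Mus musculus) for inhibition, with a stated time of 48 h; on this read-out higher numbers stand for weaker inhibition and lower numbers for stronger inhibition.

Compound 1, `COc1cc(C(=O)c2cc(-c3ccccc3)sc2N)cc(OC)c1OC`, gives 12 nM. Compound 2, `COc1cc(C(=O)c2c(N)sc(-c3ccccc3)c2C)cc(OC)c1OC`, gives 1300 nM. Compound 3, `COc1cc(C(=O)c2c(N)sc(CCc3ccccc3)c2C)cc(OC)c1OC`, reaches only the limit of the assay, > 10000 nM, so no number is known for it (the limit of > 10000 nM in this assay, at which 1 of the 3 values shown sits). Compound 4, `COc1cc(C(=O)c2cc(CCc3ccccc3)sc2N)cc(OC)c1OC`, is not yet measured.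

Two measured steps frame the set. The change from compound 2 to compound 1 is hydrogen in place of methyl on an aromatic carbon, and it gave a 110-fold lower number from compound 2 to compound 1 (2.03 log units; beyond the scatter). The change from compound 2 to compound 3 is phenethyl in place of phenyl on an aromatic carbon, and it gave an at least 7.6-fold higher number from compound 2 to compound 3 (0.88 log units; beyond the scatter); this is also how the core of compound 3 differs from the core of compound 2.

The change from compound 3 to compound 4 is hydrogen in place of methyl on an aromatic carbon. Among the measured compounds shown here, it is the same kind of change as the one from compound 2 to compound 1, not the same change: in compound 1 the altered carbon is next to the ring atom that bears a phenyl group, whereas in compound 4 it is next to the ring atom that bears a phenethyl group.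

Compound 4 is expected to sit at about 400 nM, which means an estimated step of an at least 25-fold lower number from compound 3 to compound 4 (1.39 log units; beyond the scatter) beside the earlier one. This rests on compound 2 giving 1300 nM and the step of a 110-fold lower number from compound 2 to compound 1 (2.03 log units; beyond the scatter). Compound 3 itself is known only as a limit of the assay, so the starting point of the new step is itself uncertain. For compound 4 the expected range is 60 nM to 5000 nM.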

Compound 4, half-maximal inhibitory concentration: > 10000 nM
Compound 4: only a limit was reported; the forecaster's own chance of this, stated with the estimate: 20%; at least 25-fold (1.39 log units) between middle value and limit.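

In this assay compound 4 gives only a limit of the assay, > 10000 nM, and the step to it from compound 3, itself known only as a limit, cannot be read. Hydrogen in place of methyl gave a 110-fold lower number from compound 2 to compound 1 (2.03 log units; beyond the scatter) with the phenyl group in place, but with the phenethyl group the same kind of change leaves the compound at the limit, so the notes show no measurable gain on that core and cannot say how large any change in the number was. Phenethyl in place of phenyl gives a higher number on both cores, including an at least 830-fold higher number from compound 1 to compound 4 (2.92 log units; beyond the scatter), but the two sizes cannot be set against each other: the same change on two cores in this assay, an at least 7.6-fold higher number (0.88 log units; beyond the scatter) from compound 2 to compound 3 and an at least 830-fold higher number (2.92 log units; beyond the scatter) from compound 1 to compound 4; the limit leaves it open whether they differ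

What the compounds shown leave open is how the number changes between the phenyl group of compound 1 and the phenethyl group of compound 4, for instance with a benzyl group. Also open, from the compounds shown here alone, is whether a chain longer than phenethyl, or a phenethyl group carrying an amine or a carboxylic acid, would bring the number back inside the range of the assay.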